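The compounds below may be only part of what the source reports. "The series", "measured", "known", "first", "only" and "open" are said of these compounds alone.

In an ADME assay on BJ cells (Homo sapiens) for cytotoxicity, with a stated time of 72 h (on this read-out higher numbers stand for an effect only at larger amounts of compound and lower numbers for an effect already at smaller amounts), compound 2 `COc1ccc(/C=C/[C@@](C)(/C=C/c2ccc(O)c(C=O)c2)CCC=C(C)C)cc1` gives 9800 nM. Compound 3 `COc1ccc(/C=C/[C@@](C)(/C=C/c2ccc(O)c(/C=C/C(=O)OC(C)(C)C)c2)CCC=C(C)C)cc1` gives > 36600 nM, which is a limit and not a number. Compound 1 `C=C[C@@](C)(/C=C/c1ccc(O)c(/C=C/C(=O)OCc2ccccc2)c1)CCC=C(C)C`, which carries 2-(benzyloxycarbonyl)ethenyl, gives > 36600 nM, again a limit. Going by the values given here, the one measured step is an at least 3.7-fold higher number from compound 2 to compound 3 (0.57 log units; beyond the scatter), and it comes with the exchange of formyl for 2-(tert-butoxycarbonyl)ethenyl.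

Compound 4 `COc1ccc(/C=C/[C@@](C)(/C=C/c2ccc(O)c(/C=C/C(=O)OCc3ccccc3)c2)CCC=C(C)C)cc1` has benzyl in place of tert-butyl on an oxygen next to a carbonyl group. Among the compounds with values here, no measured step covers this exchange directly, so the closest guides are the step above and the pattern across the three compounds, which shows (the limit of > 36600 nM in this assay, at which 2 of the 3 values shown sit). Compound 1 and compound 3 both sit there, and neither gives a number, so no step beyond the scatter is expected in this assay. The estimated change is a step that the limit leaves unreadable from compound 3 to compound 4, and the reading may well be a limit again. For compound 4 the expected value is 40000 nM, within an estimated range from 15000 nM to 100000 nM.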

Compound 4, half-maximal effective concentration: > 36600 nM
Compound 4: a limit, no number; the forecaster's own chance of this, stated with the estimate: 70%; the middle value is on the limit's open side.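

In this assay, the rise that came with 2-(tert-butoxycarbonyl)ethenyl also comes with 2-(benzyloxycarbonyl)ethenyl, as an at least 3.7-fold higher number from compound 2 to compound 4 (0.57 log units; beyond the scatter) shows, so at this position it is not confined to the tert-butyl version. The steps joining compound 4 to compound 3 and to compound 1 cannot be read, as each has a limit at both ends. Exchanging tert-butyl for benzyl therefore gives no measurable difference, and the compounds with these side chains all end at the same reading: the limit of > 36600 nM in this assay, at which 3 of the 4 values shown sit.

From the compounds shown here alone, how compound 1, compound 3 and compound 4 rank against one another remains unknown. Going by these compounds, it is also open whether a carboxylic acid in place of the benzyl ester, or an amine in place of the formyl group, would give a reading with an actual number.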